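A few compounds are considered here, and "the series" means these few. Any claim that something is new, unique, unknown or untested is made for them only; others in the source may bear on it.

Notes on the series. Compound 1 `CC(=O)OCc1cc(N)c(Nc2ccc(C#N)cc2)cc1Oc1c(C)cc(C#N)cc1C` and compound 2 `COCc1cc(N)c(Nc2ccc(C#N)cc2)cc1Oc1c(C)cc(/C=C/C#N)cc1C` share a core and differ from each other at two places. In a physicochemical assay for lipophilicity, read by HPLC (a lower number here means a more polar compound, a higher number a more lipophilic compound), compound 1 gives 4.4. In this assay compound 2 gives 4.13; the two values lie within the scatter of each other, so on this pair of numbers compound 2 is not separated from compound 1. Compound 3 `CC(=O)OCc1cc(N)c(Nc2ccc(C#N)cc2)cc1Oc1c(C)cc(/C=C/C#N)cc1C` has not yet been measured. It differs from compound 2 in one place: acetyl in place of methyl on an oxygen on a saturated carbon. For the measured compounds named here, no step between measured compounds isolates this change, since the comparison of compound 1 with compound 2 folds it together with the second difference. Compound 1 already carries the acetoxymethyl group and gives 4.4; that number anchors the expectation. A step from compound 2 to compound 3 of a number 0.17 log units higher from compound 2 to compound 3 (within the scatter) is expected in this assay, upward, and hardly beyond the scatter. For compound 3 the estimate in this assay is 4.3, with a range from 3.9 to 4.7.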

Compound 3, partition coefficient: 4.48
Beside the measured number, compound 3's estimate is 0.18 log units below it; low and high end bracket the measured number.
By their numbers in this assay, from the lowest: compounds 2, 1 and 3 (each within the scatter of the next, the first and the last beyond it).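

With 2-cyanoethenyl held constant on the aromatic carbon, the methyl-to-acetyl change on the oxygen can now be read alone in this assay (a number 0.35 log units higher from compound 2 to compound 3 (beyond the scatter)), which the earlier pair could not show because it also differed at a second place. With acetoxymethyl held constant, 2-cyanoethenyl in place of cyano on the aromatic carbon gives a separate reading (a number 0.08 log units higher from compound 1 to compound 3 (within the scatter)), so this change is not separated from zero in this pair. Nothing available gives a reason for either step.

As far as these compounds go, it remains open whether the step on the oxygen keeps its size when cyano stands on the aromatic carbon. From the compounds shown here alone, the reading in this assay for a free hydroxyl, a propionyl ester or an amine at the same place also remains open.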